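Fluoro for methyl on the benzoate ring of the piperidinyl esters

A few compounds are considered here, and "the series" means these few. Any claim that something is new, unique, unknown or untested is made for them only; others in the source may bear on it.

Measured so far:
compound 1 `Cc1ccc(C(=O)OC2CCN(C)CC2)cc1` with 1.17
compound 2 `CN1CCC(OC(=O)c2ccccc2C(F)(F)F)CC1` with 1.49

Both numbers come from a functional assay on the whole organism with Mus musculus as the target; on this read-out lower numbers stand for lower potency and higher numbers for higher potency (the scale is a negative logarithm). Compound 1 gives the lowest of the two values; compound 2 stands a step above it that lies beyond the usual scatter. Compound 3 `CN1CCC(OC(=O)c2ccc(F)cc2)CC1` has not yet been measured. It differs from compound 1 in one place: fluoro in place of methyl on an aromatic carbon. The change keeps the count of heavy atoms, donors, acceptors and charge unchanged and sits on an aromatic carbon of a six-membered aromatic ring of carbon only.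

Among the measured compounds shown here, no step between two measured compounds that differ only in this way is available, so nothing measured points to a direction. The expected step in this assay is small, most likely within the scatter, with at most a slight rise. The estimated step of a number 0.13 log units higher from compound 1 to compound 3 (within the scatter) reflects that. Compound 3 is therefore expected near 1.3, between 0.8 and 1.8.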

Compound 3, logarithm of the reciprocal of the active concentration, log(1/C): 1.38
Beside the measured number, compound 3's estimate is 0.08 log units below it, and the stated range covers the measured number.
By their numbers in this assay, from the lowest: compounds 1, 3 and 2 (each within the scatter of the next, the first and the last beyond it).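

In this assay, among the compounds shown here, fluoro in place of methyl on an aromatic carbon, para to a large group, gives a number 0.21 log units higher from compound 1 to compound 3 (within the scatter) and so provides the only measured step at this position. The swap of one heavy atom for another leaves the read-out of the shared core within the scatter, so this position accepts either group without a resolved change in the whole-organism number. No measurement on these compounds bears on what lies behind the step.

As far as these compounds go, whether an amine, a carboxylic acid or a longer chain on the same aromatic carbon would move the number beyond the scatter remains open. Also open, from the compounds shown here alone, is whether fluoro in place of methyl gives a similar step at another carbon of the ring or on a different core.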